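The source may hold more compounds than are shown below. What is called first, only, known or untested is meant among the compounds shown, and "the series" means these compounds.

In a functional assay for inhibition, with Rattus norvegicus as the target (on this read-out higher numbers stand for weaker inhibition and lower numbers for stronger inhibition), compound 1 `CC(/N=C(/S)Nc1cccnc1)C(C)(C)C` gives 50.1 nM and compound 2 `CC(C)(C)C/N=C(/NC#N)Nc1cccnc1` gives 100 nM, so the two values lie within the usual scatter of each other. Compound 3 `CC(/N=C(/NC#N)Nc1cccnc1)C(C)(C)C` differs from compound 2 by methyl in place of hydrogen on a saturated chain carbon bound to a double-bonded nitrogen and a saturated chain carbon, which turns neopentyl into 1,2,2-trimethylpropyl. Within the data shown here, compound 1 carries that same chain and gives 50.1 nM, though no measured pair isolates this change. The estimated 1.6-fold lower number from compound 2 to compound 3 (0.20 log units; within the scatter) is small, toward a lower number in this assay, and possibly none beyond the scatter. For compound 3 the expected value is 63 nM, with an estimated range of 20 nM to 200 nM.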

Compound 3, half-maximal inhibitory concentration: 15.9 nM
Compound 3: middle estimate off by 4.0-fold (0.60 log units), on the high side; the whole stated range lies above it.
By their numbers in this assay, from the lowest: compound 3; then compounds 1 and 2 (each within the scatter of the next).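

In this assay, methyl in place of hydrogen on a saturated chain carbon bound to a double-bonded nitrogen and a saturated chain carbon now has a measured pair of its own, showing a 6.3-fold lower number from compound 2 to compound 3 (0.80 log units; beyond the scatter) at this position. Among these compounds, with 1,2,2-trimethylpropyl held the same, cyanoamino in place of sulfanyl shows a 3.2-fold lower number from compound 1 to compound 3 (0.50 log units; beyond the scatter) in a comparison the earlier compounds did not offer. No measured evidence accounts for either step.

Open, from the compounds shown here alone, is whether ethyl in place of that methyl would give a similar step, and how an amine or a carboxylic acid in place of cyanoamino would read out.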